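Cytotoxicity notes on a cyclohexyl-to-benzyl swap

This account rests on a few compounds, and the source may have more. Where it says the series, first, only, none or still open, it means among the compounds named here.

Measured compounds:
- compound 1 `FC(F)(F)Oc1ccc(Nc2ncnc3c2cnn3C2CCCCC2)cc1`: 9300 nM
- compound 2 `Fc1ccc(Nc2cc(-c3ccncc3)ncn2)cc1`: > 10000 nM

Among the compounds with values here, in an ADME assay on BaF3 cells (Mus musculus) for cytotoxicity (a lower number here means that less compound is needed, a higher number that more compound is needed for the effect), compound 1 gives 9300 nM, the only number recorded. Compound 2 reaches only (the limit of > 10000 nM in this assay, at which 1 of the 2 values shown sits), so its result is a limit rather than a number. Within the data shown here, compound 1 therefore stands alone as the single quantified point; the pair offers no step between measured compounds.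

Compound 3 `FC(F)(F)Oc1ccc(Nc2ncnc3c2cnn3Cc2ccccc2)cc1` differs from compound 1 by benzyl in place of cyclohexyl on an aromatic nitrogen. Among the measured compounds shown here, no measured step of this kind exists, and the change keeps the rest of the structure untouched. In this assay compound 3 is expected to sit close to compound 1, with a step from compound 1 to compound 3 of a 1.2-fold lower number from compound 1 to compound 3 (0.07 log units; within the scatter), which is not beyond the usual scatter. Compound 3 is estimated at 8000 nM, with a range from 3000 nM to 20000 nM.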

Compound 3, half-maximal effective concentration: > 10000 nM
Compound 3: a limit, no number; the forecaster's own chance of this, stated with the estimate: 30%; middle value at least 1.2-fold (0.09 log units) away from the limit.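

Compound 3 gives > 10000 nM in this assay, which is a limit and not a number. With benzyl in place of cyclohexyl on an aromatic nitrogen, the series gains its first step at this position, an at least 1.0-fold higher number from compound 1 to compound 3 (0.03 log units; that floor lies within the scatter), and the change does not bring the result to a quantified value below the limit. The true size of the step stays unknown, and compound 1 remains the only quantified point in the series: the limit of > 10000 nM in this assay, at which 2 of the 3 values shown sit.

The compounds shown leave open whether an amine, a carboxylic acid or a longer chain such as phenylethyl on this aromatic nitrogen would give a quantified value in this assay. They also leave open how far above the limit compound 3 lies, so the step has only a floor.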